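Swapping a Hydroxy for a Chloro on the Shared Core

The source may hold more compounds than are shown below. What is called first, only, known or untested is meant among the compounds shown, and "the series" means these compounds.

Compound 3 `Oc1ccc(-c2nc(-c3c[nH]c4ccccc34)co2)cc1` gives 382000 nM in a functional assay on PC-3 cells (Homo sapiens) for cytotoxicity, read by MTT assay, with a stated time of 48 h (a lower number here means a stronger inhibitor, a higher number a weaker inhibitor), the highest of the three numbers shown. Compound 2 `Cc1nc(-c2c[nH]c3ccccc23)co1` gives 337000 nM, and the step of a 1.1-fold higher number from compound 2 to compound 3 (0.05 log units; within the scatter) is within the scatter, so these two cannot be ordered. Compound 1 `c1ccc(-c2nc(-c3c[nH]c4ccccc34)co2)cc1` gives 170000 nM, and the step of a 2.2-fold higher number from compound 1 to compound 3 (0.35 log units; beyond the scatter) is modest. Compound 4 `Clc1ccc(-c2nc(-c3c[nH]c4ccccc34)co2)cc1` has not yet been measured; the change from compound 3 is chloro in place of hydroxy on an aromatic carbon. For the measured compounds named here, no measured step adds a chloro, so only the step of a 2.2-fold higher number from compound 1 to compound 3 (0.35 log units; beyond the scatter) bears on it: removing the hydroxy is expected to roughly undo that modest step, giving an expected step of a 1.9-fold lower number from compound 3 to compound 4 (0.28 log units; within the scatter). Compound 4 is therefore estimated at 200000 nM, with a range from 80000 nM to 500000 nM.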

Compound 4, half-maximal inhibitory concentration: 151000 nM
For compound 4 the middle estimate is 1.3-fold (0.12 log units) above the measured one, within the range that was stated.
By their numbers in this assay, from the lowest: compounds 4, 1, 2 and 3 (each within the scatter of the next, the first and the last beyond it).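

In this assay, replacing the hydroxy with chloro at this position, para to a large group, gives a modest change (a 2.5-fold lower number from compound 3 to compound 4 (0.40 log units; beyond the scatter)), and the 4-chlorophenyl group also separates from methyl (a 2.2-fold lower number from compound 2 to compound 4 (0.35 log units; beyond the scatter)). Chloro cannot be told apart from hydrogen (a 1.1-fold lower number from compound 1 to compound 4 (0.05 log units; within the scatter)), so among hydrogen, hydroxy and chloro here, only the hydroxy shifts the number. Nothing available explains this difference. Going by these compounds, whether an amine, a methoxy or a carboxylic acid at this position would shift the number remains open.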